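Chloro for methoxy on the fused benzene ring

The compounds below may be only part of what the source reports. "The series", "measured", "known", "first", "only" and "open" are said of these compounds alone.

Two compounds of the series carry a number in a functional assay on the whole organism with Rattus norvegicus as the target, with a stated time of 3 h, at a dose of 200 mg/kg by the oral route; a lower number here means less inhibition, a higher number more inhibition at the dose given (going by the name of the read-out). Compound 1 `Cc1ccc2[nH]c(-c3cccc(C)n3)nc2c1` gives 67%, and compound 2 `COc1ccc2[nH]c(-c3cccc(C)n3)nc2c1` gives 39%. Among the measured compounds shown here, compound 2 thus stands lowest of the two, the only step among measured compounds being a number 28 percentage points lower from compound 1 to compound 2 (beyond the scatter), a modest change attached to a single exchange on that aromatic carbon. Compound 3 `Cc1cccc(-c2nc3cc(Cl)ccc3[nH]2)n1` is not yet measured; it differs from compound 2 by chloro in place of methoxy on an aromatic carbon. For the measured compounds named here, no measured step has chloro entering or methoxy leaving toward anything but methyl, so the one step that bears on it is the exchange at the same position, which moved the read-out by a number 28 percentage points lower from compound 1 to compound 2 (beyond the scatter). A step of comparable size, in either direction, is therefore plausible, and the estimate leans upward because compound 1 with methyl gave 67%. Compound 3 is expected at 55% (range 30% to 80%), an estimated step of a number 16 percentage points higher from compound 2 to compound 3 (beyond the scatter).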

Compound 3, a percentage reported as inhibition, in the whole organism at one dose (the size of the read-out at that dose, not a potency): 95%
For compound 3 the middle estimate is 40 percentage points below the measured one; the measured number lies above the stated range.
By their numbers in this assay, from the lowest: compound 2; then compound 1; then compound 3.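

In this assay, among the compounds shown here, the exchange of methoxy for chloro on this aromatic carbon gives the largest step so far, with a number 56 percentage points higher from compound 2 to compound 3 (beyond the scatter) as its size. Chloro also outruns methyl at the same place, with a number 28 percentage points higher from compound 1 to compound 3 (beyond the scatter) as the step, so the methyl of compound 1 does not mark the top of what this position allows. Compound 3 now stands highest of the three, the order from the lowest being methoxy, methyl, chloro, and no measurement shown speaks to what lies behind that order.

Still open, from the compounds shown here alone, is how other groups on this carbon would place in that order, such as bromo, trifluoromethyl, an amine or a carboxylic acid. Also open, going by these compounds, is whether the order would persist with the methyl on the pyridine-side ring of the shared core replaced by a longer chain.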